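The source may hold more compounds than are shown below. What is called first, only, known or untested is meant among the compounds shown, and "the series" means these compounds.

The measured compounds:

compound 1 `COc1cc(-c2cc3cc(C(C)N(O)C(C)=O)ccc3o2)cc(OC)c1OC`, which in an assay on RBL cells for inhibition of Polyunsaturated fatty acid 5-lipoxygenase (Rattus norvegicus) (a higher number here means a weaker inhibitor, a lower number a stronger inhibitor), gives 310 nM
compound 2 `CC(c1ccc2oc(-c3ccccc3)cc2c1)N(O)C(=O)c1ccccc1`, which in this assay gives 4830 nM

Compound 2 has the higher of the two numbers and is therefore the weaker inhibitor. For the measured compounds named here, its only neighbour in this assay is compound 1, whose value stands well below it, beyond the usual scatter. Going by the values given here, the two compounds differ in more than one place, so no single structural step connects them, and their values say only that compound 1 binds much more tightly.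

Compound 3 `COc1cccc(OC)c1C(=O)N(O)C(C)c1ccc2oc(-c3ccccc3)cc2c1` differs from compound 2 in one place: 2,6-dimethoxyphenyl in place of phenyl on a carbonyl carbon. Among the compounds with values here, no measured pair here shows the effect of such a change, so the expectation rests on compound 2 alone. With nothing in the data pointing either way, the step of a 1.2-fold lower number from compound 2 to compound 3 (0.08 log units; within the scatter) is expected to stay within the scatter, with a wide uncertainty on both sides. Compound 3 is therefore estimated to give 4000 nM in this assay, somewhere between 1200 nM and 13000 nM.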

Compound 3, half-maximal inhibitory concentration: 3000 nM
The estimate for compound 3 lay 1.3-fold (0.12 log units) above the measured number; low and high end bracket the measured number.
By their numbers in this assay, from the lowest: compound 1; then compounds 3 and 2 (each within the scatter of the next).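

Putting 2,6-dimethoxyphenyl in place of phenyl on a carbonyl carbon gives a 1.6-fold lower number from compound 2 to compound 3 (0.21 log units; within the scatter) in this assay. For the compounds shown here, this is the first direct reading of this position: the entering group has more heavy atoms than phenyl and brings hydrogen-bond acceptors that phenyl lacks, yet the step stays within the scatter, so this assay cannot tell the two compounds apart. No outside measurement is available to explain this result.

From the compounds shown here alone, neither compound 2 nor compound 3 is a single step from compound 1, so what sets the value of compound 1, 310 nM, remains open. Going by these compounds, it also remains open whether this carbonyl carbon would accept a very different group just as readily, for example a phenyl ring carrying a carboxylic acid or a dimethylamino group, since a single step with two methoxy groups says nothing about such replacements.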